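Methyl on the shared core: one step, measured twice

The source may hold more compounds than are shown below. What is called first, only, known or untested is meant among the compounds shown, and "the series" means these compounds.

Measured so far in a functional assay on A-431 cells (Homo sapiens) for cytotoxicity, read by MTT assay, with a stated time of 72 h, tested at 10 uM; on this read-out lower numbers stand for less inhibition of growth and higher numbers for more inhibition of growth at the one concentration tested:
compound 1 `N/C(=N\NC(=S)N1CCCCCC1)c1ccccn1`: 67%
compound 2 `N/C(=N\NC(=S)N1CCOCC1)c1ccccn1`: 69.4%
compound 3 `Cc1cccc(/C(N)=N/NC(=S)N2CCOCC2)n1`: 68.1%

The three values of compound 1, compound 2 and compound 3 lie within the usual scatter of one another, so no order among them is claimed. The difference between the cores of compound 1 and compound 2 is not broken down here. From compound 2 to compound 3 the change is methyl in place of hydrogen on an aromatic carbon, and the step is a number 1.3 percentage points lower from compound 2 to compound 3 (within the scatter).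

Compound 4 `Cc1cccc(/C(N)=N/NC(=S)N2CCCCCC2)n1` carries the same change relative to compound 1, namely (methyl in place of hydrogen on an aromatic carbon); the place is the same word for word as in the pair above. Because the measured step of a number 1.3 percentage points lower from compound 2 to compound 3 (within the scatter) stays within the scatter, the step from compound 1 to compound 4 in this assay is expected to be a number 1 percentage points lower from compound 1 to compound 4 (within the scatter). Compound 4 is therefore estimated at 66%, with an expected range from 56% to 76%.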

Compound 4, percent growth inhibition at one concentration: 45.8%
The estimate for compound 4 lay 20.2 percentage points above the measured number, outside the stated range (below it).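

In this assay, methyl in place of hydrogen on an aromatic carbon gives a number 21.2 percentage points lower from compound 1 to compound 4 (beyond the scatter). The size of this step does not carry from one core to the other: the same change on two cores in this assay, a number 1.3 percentage points lower (within the scatter) from compound 2 to compound 3 and a number 21.2 percentage points lower (beyond the scatter) from compound 1 to compound 4, 19.9 percentage points apart, beyond the scatter of two such steps

So in these two pairs the outcome of the same change depends on the core it sits on. Two pairs read at one concentration do not show why, nor how the step would fall on any further core.

Still open, as far as these compounds go, is whether the drop on the core of compound 1 is specific to methyl or also appears with ethyl, chlorine, methoxy or an amine at the same place.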